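One Phenyl Fewer in a Weakly Inhibiting Pair

A few compounds are considered here, and "the series" means these few. Any claim that something is new, unique, unknown or untested is made for them only; others in the source may bear on it.

Among the compounds with values here, compound 1 `CCC(C)C(NC(=O)NO)C(=O)NC(c1ccccc1)c1ccccc1` gives the higher of the two numbers measured so far in a functional assay on WI-38 cells (Homo sapiens) for inhibition (a lower number here means a stronger inhibitor, a higher number a weaker inhibitor), with 95800 nM. Compound 2 `CCC(C)C(NC(=O)n1nnc2ccccc21)C(=O)NC(c1ccccc1)c1ccccc1` gives 62700 nM in this assay, and the step of a 1.5-fold lower number from compound 1 to compound 2 (0.18 log units; within the scatter) lies within the scatter. Compound 3 `CCC(C)C(NC(=O)NO)C(=O)NCc1ccccc1` differs from compound 1 by hydrogen in place of phenyl on a saturated chain carbon bound to an amide-type nitrogen and an aromatic carbon. Within the data shown here, the single measured step alters the group on the carbonyl carbon and leaves the carbon bearing the phenyl untouched, so no measured step bears on this change, and no movement beyond the scatter is expected in this assay. The expected step is a 1.1-fold higher number from compound 1 to compound 3 (0.06 log units; within the scatter). Compound 3 is therefore estimated at 110000 nM, between 40000 nM and 300000 nM.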

Compound 3, half-maximal inhibitory concentration: > 100000 nM
Compound 3 ended at the assay's limit; the forecaster's own chance of this, stated with the estimate: 20%; the middle value lies beyond the limit too.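

Set in this assay, the change of phenyl to hydrogen on a saturated chain carbon bound to an amide-type nitrogen and an aromatic carbon gives an at least 1.0-fold higher number from compound 1 to compound 3 (0.01 log units; that floor lies within the scatter), the first reading at this position. Compound 3 gives > 100000 nM, which is a limit of the assay and not a number. The size of the step therefore stays unknown, because the reading stops at that limit: the limit of > 100000 nM in this assay, at which 1 of the 3 values shown sits.

Going by these compounds, whether a methyl or a cyclohexyl on this carbon would bring a step beyond the scatter remains open. Also open, on these data alone, is whether the change would read the same with the carbonyl group of compound 2.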